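Fluoro in place of 4-methylpiperazin-1-yl on an aromatic carbon

The compounds below may be only part of what the source reports. "The series", "measured", "known", "first", "only" and "open" are said of these compounds alone.

Compound 2 `COc1cc(OC)c(C(=O)/C=C/c2cccc(N3CCN(C)CC3)c2)c(O)c1CC=C(C)C` stands at the edge of what this series can report: in an ADME assay on MCF7-DOX cells (Homo sapiens) for cytotoxicity, read by MTT assay, with a stated time of 48 h (a lower number here means a stronger inhibitor, a higher number a weaker inhibitor), compound 2 gives > 100000 nM, and that figure is a limit of the assay rather than a number (the limit of > 100000 nM in this assay, at which 1 of the 2 values shown sits). Compound 1 `COc1cc(OC)c(C(=O)/C=C/c2cccc(Cl)c2)c(O)c1CC=C(C)C` carries chloro on the same aromatic carbon, and in this assay compound 1 gives 59500 nM. Among the compounds with values here, the single measured step, an at least 1.6-fold higher number from compound 1 to compound 2 (0.22 log units; that floor lies within the scatter), is the only guide, and its floor lies within the scatter, so the true gap between the two could be small or large.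

Compound 3 `COc1cc(OC)c(C(=O)/C=C/c2cccc(F)c2)c(O)c1CC=C(C)C` has not yet been measured in this assay. It differs from compound 2 by fluoro in place of 4-methylpiperazin-1-yl on an aromatic carbon. Because compound 1 with chloro gave 59500 nM, a halogen is expected to bring the number back into the measurable range, so the expected step is an at least 1.4-fold lower number from compound 2 to compound 3 (0.15 log units; that floor lies within the scatter), downward. For compound 3 the estimate in this assay is 70000 nM, with a range from 30000 nM to 160000 nM.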

Compound 3, half-maximal inhibitory concentration: 45400 nM
The estimate for compound 3 lay 1.5-fold (0.19 log units) above the measured number; measured number inside the range.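

In this assay, fluoro in place of 4-methylpiperazin-1-yl on this aromatic carbon gives an at least 2.2-fold lower number from compound 2 to compound 3 (0.34 log units; beyond the scatter), so a step at this position now clears the scatter, which the floor of the earlier step from chloro did not. The size of this step is itself only a floor, since compound 2 sits at a limit of the assay and not at a number: the limit of > 100000 nM in this assay, at which 1 of the 3 values shown sits. The two halogens are not separated at this position, as fluoro in place of chloro gives a 1.3-fold lower number from compound 1 to compound 3 (0.12 log units; within the scatter).

The compounds shown leave open how wide the gap to compound 2 really is. They also leave open whether a simple amine such as dimethylamino, or a carboxylic acid, on this aromatic carbon would read like the two halogens or would reach the limit as compound 2 does.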